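A few compounds are considered here, and "the series" means these few. Any claim that something is new, unique, unknown or untested is made for them only; others in the source may bear on it.

Compound 1 `ICc1cn(Cc2ccccc2)nn1` gives 2 ug/mL in a functional assay on HeLa cells (Homo sapiens), read by colorimetric assay, with a stated time of 72 h; a higher number here means that more compound is needed for the effect, a lower number that less compound is needed. Compound 2 `CC(=O)N[C@@H]1[C@@H](OC(C)=O)[C@H](OC(C)=O)[C@@H](COC(C)=O)O[C@H]1n1cc(CO)nn1` is a different case: in this assay compound 2 gives > 100 ug/mL, which is a limit of the assay and not a number, so compound 2 sits at the limit of > 100 ug/mL in this assay, at which 1 of the 2 values shown sits. Compound 3 `CC(=O)N[C@@H]1[C@@H](OC(C)=O)[C@H](OC(C)=O)[C@@H](COC(C)=O)O[C@H]1n1nnc(CO)c1CO` has not been measured yet; it differs from compound 2 by hydroxymethyl in place of hydrogen on an aromatic carbon. Going by the values given here, no measured pair shows what this change does, so a step that the limit leaves unreadable from compound 2 to compound 3 is expected to be none beyond the scatter. Compound 3 is therefore estimated at 150 ug/mL in this assay, within 50 ug/mL to 500 ug/mL, most probably reported again as a limit.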

Compound 3, concentration for half-maximal effect: > 100 ug/mL
Compound 3: no number, only a limit; the forecaster's own chance of this, stated with the estimate: 85%; the middle value does not contradict the limit.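

Compound 2 and compound 3 both stand at a limit, not a number, in this assay, so no step between them can be read: the limit of > 100 ug/mL in this assay, at which 2 of the 3 values shown sit.

On these data alone, whether hydroxymethyl in place of hydrogen on an aromatic carbon changes the effect at all stays open.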